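Swapping Azetidin-1-yl for Cyclohexylamino on a Shared Core

This account rests on a few compounds, and the source may have more. Where it says the series, first, only, none or still open, it means among the compounds named here.

Of the compounds shown here, three sharing one core have been tested in a functional assay on MGC-803 cells (Homo sapiens) for inhibition, read by sulforhodamine B assay; on this read-out higher numbers stand for weaker inhibition and lower numbers for stronger inhibition. Compound 1 `O=C1C=C(NCc2ccccc2)C(=O)c2c1nc1n2[C@H]2OC[C@@H](O)[C@H]2OC1`, which carries benzylamino, gives 2670 nM, and compound 3 `CCc1ccc(NC2=CC(=O)c3c(nc4n3[C@H]3OC[C@@H](O)[C@H]3OC4)C2=O)cc1` gives 1110 nM. Compound 2 `O=C1C=C(N2CCC2)C(=O)c2c1nc1n2[C@H]2OC[C@@H](O)[C@H]2OC1`, which carries azetidin-1-yl, gives > 16000 nM, and this is a limit of the assay, not a number. From the compounds shown here alone, compound 2 therefore stands at the limit of > 16000 nM in this assay, at which 1 of the 3 values shown sits, so its true value is unknown.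

The next molecule, compound 4 `O=C1C=C(NC2CCCCC2)C(=O)c2c1nc1n2[C@H]2OC[C@@H](O)[C@H]2OC1`, has cyclohexylamino in place of azetidin-1-yl on a double-bonded ring carbon.

Among the measured compounds shown here, one measured step bears directly on this change, and it involves the same azetidin-1-yl group. Putting azetidin-1-yl in place of benzylamino gave an at least 5.9-fold higher number from compound 1 to compound 2 (0.77 log units; beyond the scatter). Compound 4 undoes a change of that kind, so a step of similar size in the opposite direction, towards stronger inhibition, is expected in this assay. This expectation holds because compound 1 with its benzylamino group gives 2670 nM, and cyclohexylamino resembles benzylamino more closely than azetidin-1-yl does. The expected change is an at least 4.5-fold lower number from compound 2 to compound 4 (0.66 log units; beyond the scatter). The starting point is only a limit. The size of this step remains uncertain. The estimate for compound 4 is 3500 nM, with an expected range from 1300 nM to 11000 nM.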

Compound 4, half-maximal inhibitory concentration: > 8000 nM
Compound 4: only a limit was reported; the forecaster's own chance of this, stated with the estimate: 10%; middle value at least 2.2-fold (0.35 log units) from the limit.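

Compound 4 stops at a limit of the assay, not a number: the limit of > 8000 nM in this assay, at which 1 of the 4 values shown sits. In this assay, cyclohexyl in place of benzyl on an amine nitrogen still gives a readable result, an at least 2.9-fold higher number from compound 1 to compound 4 (0.47 log units; beyond the scatter), so at this double-bonded ring carbon these two ring-bearing amino groups are not interchangeable. The result also shows that weak inhibition at this position is not confined to azetidin-1-yl: cyclohexylamino keeps a hydrogen-bond donor on its nitrogen, yet compound 4 is still weaker than compound 1, while the step between compound 2 and compound 4 cannot be read, as both values are limits.

From the compounds shown here alone, the true order of compound 2 and compound 4 stays unknown, and with it whether cyclohexylamino does any better than azetidin-1-yl at this carbon. Also open, going by these compounds, is how the series would respond to other amines at the same place, such as morpholine or a simple open-chain butylamine, which would help show whether the benzyl group's aromatic ring matters or whether a longer chain on the nitrogen could serve equally well.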